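Lengthening the Side Chain of an Aldehyde Dehydrogenase Inhibitor

A few compounds are considered here, and "the series" means these few. Any claim that something is new, unique, unknown or untested is made for them only; others in the source may bear on it.

Of the compounds shown here, three sharing one core have been tested in an assay (Cricetulus griseus) for inhibition of aldehyde dehydrogenase, mitochondrial (Homo sapiens); on this read-out lower numbers stand for stronger inhibition and higher numbers for weaker inhibition. Compound 3 `CCOc1ccc2c(=O)c(-c3ccc(O)cc3)coc2c1` gives 80 nM. Compound 2 `CCOC(=O)COc1ccc2c(=O)c(-c3ccc(O)cc3)coc2c1` gives 130 nM in this assay; the two cores differ by ethoxycarbonyl in place of methyl on a saturated chain carbon bound to an oxygen on an aromatic ring, and the step of a 1.6-fold lower number from compound 2 to compound 3 (0.21 log units; within the scatter) separates them. Compound 1 `CCCCCCOc1ccc2c(=O)c(-c3ccc(O)cc3)coc2c1` gives 1500 nM; it arises from compound 3 by butyl in place of hydrogen on a saturated chain carbon, two bonds along the chain from an oxygen on an aromatic ring, a change that produced a 19-fold higher number from compound 3 to compound 1 (1.27 log units; beyond the scatter).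

Compound 4 `CCCCC(Oc1ccc2c(=O)c(-c3ccc(O)cc3)coc2c1)C(=O)OCC` has not yet been measured. It arises from compound 2 by butyl in place of hydrogen on a saturated chain carbon bound to a carbonyl carbon and an oxygen on an aromatic ring. For the measured compounds named here, this is the same kind of change as the one from compound 3 to compound 1, but the place is not identical: in compound 1 the butyl sits on a saturated chain carbon, two bonds along the chain from an oxygen on an aromatic ring, whereas in compound 4 it sits on a saturated chain carbon bound to a carbonyl carbon and an oxygen on an aromatic ring. Compound 4 is expected to show a 6.9-fold higher number from compound 2 to compound 4 (0.84 log units; beyond the scatter), because a 19-fold higher number from compound 3 to compound 1 (1.27 log units; beyond the scatter) points the same way, though the different surroundings leave the size uncertain. Compound 4 is therefore estimated at 900 nM, plausibly between 250 nM and 3500 nM.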

Compound 4, half-maximal inhibitory concentration: 4500 nM
The estimate for compound 4 lay 5.0-fold (0.70 log units) below the measured number; the whole stated range lies below it.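

Putting butyl in place of hydrogen on the saturated chain carbon bound to a carbonyl carbon and an oxygen on an aromatic ring gives a 35-fold higher number from compound 2 to compound 4 (1.54 log units; beyond the scatter) in this assay, so inhibition becomes clearly weaker. The same change has now been seen on two cores, and the two steps agree in direction and do not differ in size: the same change on two cores in this assay, a 19-fold higher number (1.27 log units; beyond the scatter) from compound 3 to compound 1 and a 35-fold higher number (1.54 log units; beyond the scatter) from compound 2 to compound 4, 1.8-fold (0.27 log units) apart, within the scatter of two such steps

In this pair of cores, the effect of the change therefore carried over even though the butyl sits at a different place in each, but two pairs cannot show that it would hold on other cores, and they do not explain why the number rises.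

On these data alone, it remains open how a methyl or a chain longer than butyl would behave in place of butyl on that same carbon. As far as these compounds go, it is also open whether a carboxylic acid in place of the ethoxycarbonyl would change the size of the step.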